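The source may report more compounds than this note shows. Statements on the series, on what has been measured and on what is new or still open speak of the compounds shown alone.

Compound 1 `C1CCCC2(CC1)OOC1(CCCCCC1)OO2` gives > 100 ug/mL
Compound 2 `CCS(=O)(=O)N1CCC2(CC1)OOC1(CCCC1)OO2` gives > 100 ug/mL

In a functional assay on Huh-7 cells (Homo sapiens) for cytotoxicity, read by MTT assay, with a stated time of 72 h (on this read-out higher numbers stand for lower toxicity in this test and lower numbers for higher toxicity in this test), compound 2 gives > 100 ug/mL as a limit of the assay, so it has no exact number. Compound 1 gives > 100 ug/mL as a limit too. Compound 3 `COc1ccc(S(=O)(=O)N2CCC3(CC2)OOC2(CCCC2)OO3)cc1` shares the core of compound 2 and changes in one place (4-methoxyphenyl in place of ethyl on a sulfonyl sulfur), with 4-methoxyphenyl in place of ethyl on a sulfonyl sulfur. Going by the values given here, no measured pair shows such a change. The expected step (an at least 1.1-fold lower number from compound 2 to compound 3 (0.04 log units; that floor lies within the scatter)) is small, towards somewhat higher toxicity if any, and may stay within the usual scatter. For compound 3 the estimated half-maximal cytotoxic concentration is 90 ug/mL, with 35 ug/mL to 200 ug/mL as the expected range.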

Compound 3, half-maximal cytotoxic concentration: > 100 ug/mL
Compound 3 ended at the assay's limit (the forecaster's own chance of this, stated with the estimate: 55%); middle value at least 1.1-fold (0.04 log units) away from the limit.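

No step can be read from compound 2 to compound 3 in this assay, because both results are limits rather than numbers: the limit of > 100 ug/mL in this assay, at which 3 of the 3 values shown sit.

The compounds shown leave open whether 4-methoxyphenyl in place of ethyl on a sulfonyl sulfur changes the result at all, and what exact number each compound would give.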